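Methylation of the ring amide nitrogen across two cores

The compounds below may be only part of what the source reports. "The series", "measured", "known", "first", "only" and "open" are said of these compounds alone.

Compound 1 `O=C1CN(C2CCCC2)c2nc(Nc3ccc(N4CCCCC4)cc3)ncc2N1` and compound 3 `CN1C(=O)CN(C2CCCC2)c2nc(Nc3ccc(N4CCCCC4)cc3)ncc21` share one core; compound 2 `CN1CCN(c2ccc(Nc3ncc4c(n3)N(C3CCCC3)CC(=O)N4)nc2)CC1` and compound 4 `CN1CCN(c2ccc(Nc3ncc4c(n3)N(C3CCCC3)CC(=O)N4C)nc2)CC1` share another. The difference between the two cores is not broken down here.

In a functional assay on HCT-116 cells (Homo sapiens) for inhibition, read by MTT assay, with a stated time of 48 h (a higher number here means a weaker inhibitor, a lower number a stronger inhibitor), compound 1 gives 4440 nM. Compound 3 gives 6100 nM in this assay. The change between them is methyl in place of hydrogen on an amide-type nitrogen in a ring, and the step it made is a 1.4-fold higher number from compound 1 to compound 3 (0.14 log units; within the scatter). Compound 2 in this assay gives only a limit, > 30000 nM; this is the situation described by the limit of > 30000 nM in this assay, at which 1 of the 3 values shown sits.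

The change from compound 2 to compound 4 is methyl in place of hydrogen on an amide-type nitrogen in a ring, the same change as from compound 1 to compound 3, at a place described in the same words. On the first core that change moved the value by no more than the usual scatter, so on the second core the expectation is likewise a small step, and the expected step from compound 2 to compound 4 in this assay is a step that the limit leaves unreadable from compound 2 to compound 4. As compound 2 returned only a limit, the expected outcome for compound 4 is most likely again a limit rather than a number. Taking the change as roughly neutral, compound 4 is estimated at 45000 nM in this assay, with a range from 20000 nM to 120000 nM.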

Compound 4, half-maximal inhibitory concentration: 9730 nM
The estimate for compound 4 lay 4.6-fold (0.67 log units) above the measured number, outside the stated range (below it).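

In this assay, methyl in place of hydrogen on an amide-type nitrogen in a ring gives an at least 3.0-fold lower number from compound 2 to compound 4 (0.48 log units; beyond the scatter), whereas on the core of compound 1 the same change gives a 1.4-fold higher number from compound 1 to compound 3 (0.14 log units; within the scatter), so the change cannot be treated as neutral on every core in this series: the same change on two cores in this assay, a 1.4-fold higher number (0.14 log units; within the scatter) from compound 1 to compound 3 and an at least 3.0-fold lower number (0.48 log units; beyond the scatter) from compound 2 to compound 4, at least 4.2-fold (0.62 log units) apart, beyond the scatter of two such steps.
Compound 2 gives only a limit, > 30000 nM, and the step that starts from it therefore has no fixed size, only a least size.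
These two pairs show that the result of this change did not carry over from one core to the other in this assay, but they do not show what in the cores sets the difference, nor that the same split would hold on any further core.

What stays open is which part of the difference between the two cores goes with the different steps, as the pairs shown differ in more than one place from each other. As far as these compounds go, it also stays open whether an ethyl group or a longer chain on the same nitrogen would follow the methyl group on either core.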